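The compounds below may be only part of what the source reports. "The series", "measured", "known", "first", "only" and "open" are said of these compounds alone.

Measured in a functional assay on NCI-H460 cells (Homo sapiens) for cytotoxicity, read by MTT assay, with a stated time of 72 h; a lower number here means a stronger inhibitor, a higher number a weaker inhibitor:
- Compound 1 `CC(C)(C)c1[nH]cnc1/C=c1\[nH]c(=O)/c(=C/c2cccc(C(=O)c3ccc(F)cc3)c2)[nH]c1=O`: 3.8 nM
- Compound 2 `O=C(c1ccc(F)cc1)c1cccc(/C=c2\[nH]c(=O)/c(=C/c3c[nH]cn3)[nH]c2=O)c1`: 278 nM
- Compound 3 `COCc1ccc(/C=c2\[nH]c(=O)/c(=C/c3cccc(Oc4ccc(F)cc4)c3)[nH]c2=O)o1`: 14 nM

Compound 3, at 14 nM, stands in the middle of this set, with a number higher than that of compound 1 and lower than that of compound 2. Compound 4 `COCc1ccc(/C=c2\[nH]c(=O)/c(=C/c3cccc(C(=O)c4ccc(F)cc4)c3)[nH]c2=O)o1` departs from compound 3 by one change, (4-fluorophenyl)carbonyl in place of 4-fluorophenoxy on an aromatic carbon.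

For the measured compounds named here, no measured step makes this exchange. Going by the values given here, the only step available is a 73-fold higher number from compound 1 to compound 2 (1.86 log units; beyond the scatter), a large one, but it concerns hydrogen in place of tert-butyl elsewhere in the molecule and so bears on this change only indirectly. Both of its compounds carry the entering group: compound 1 gives 3.8 nM and compound 2 gives 278 nM. The group therefore occurs at both low and high numbers, and nothing here points to a direction. The estimated step is a 1.2-fold lower number from compound 3 to compound 4 (0.07 log units; within the scatter), which is expected to stay within the scatter. For compound 4 the expected value is 12 nM, with an estimated range of 4 nM to 40 nM.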

Compound 4, half-maximal inhibitory concentration: 2.9 nM
Estimate against measurement, compound 4: 4.1-fold (0.62 log units) above; the whole stated range lies above it.
By their numbers in this assay, from the lowest: compounds 4 and 1 (each within the scatter of the next); then compound 3; then compound 2.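

In this assay the exchange of 4-fluorophenoxy for (4-fluorophenyl)carbonyl on an aromatic carbon gives a 4.8-fold lower number from compound 3 to compound 4 (0.68 log units; beyond the scatter) and so shows that this position responds to the change when the 5-(methoxymethyl)furan-2-yl group is present. With (4-fluorophenyl)carbonyl held constant, 5-(methoxymethyl)furan-2-yl in place of 1H-imidazol-4-yl gives a 96-fold lower number from compound 2 to compound 4 (1.98 log units; beyond the scatter) while the same group in place of 5-(tert-butyl)-1H-imidazol-4-yl gives a 1.3-fold lower number from compound 1 to compound 4 (0.12 log units; within the scatter) and this second step stays within the scatter. These two groups therefore cannot be ordered in this setting, and only 1H-imidazol-4-yl stands apart from them.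

As far as these compounds go, whether the exchange moves the number the same way with an imidazole group present stays open, as does what an amine or a carboxylic acid would give on this aromatic carbon. Nothing measured here accounts for these steps.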